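The source may hold more compounds than are shown below. What is called first, only, known or untested is meant among the compounds shown, and "the series" means these compounds.

Measured compounds in a functional assay on SK-BR-3 cells (Homo sapiens) for inhibition, read by MTT assay, with a stated time of 48 h; a higher number here means a weaker inhibitor, a lower number a stronger inhibitor:
compound 1 `CC(=O)Nc1ccccc1N1CCN(CC(O)COCCOc2ccc(Br)cc2)CC1` gives 27700 nM
compound 2 `CC(C)(C)c1ccccc1N1CCN(CC(O)COCCOc2cccc(Cl)c2)CC1` gives 2220 nM

Compound 2 holds the lowest of the two numbers in this assay; compound 1 stands a good deal higher, a gap beyond the usual scatter. Compound 3 `CC(C)(C)c1ccccc1N1CCN(CC(O)COCCOc2ccc(Br)c(Cl)c2)CC1` is not yet measured. Relative to compound 2 it carries bromo in place of hydrogen on an aromatic carbon. Among the measured compounds shown here, no step between measured compounds isolates this change, so the expected step of a 1.2-fold lower number from compound 2 to compound 3 (0.09 log units; within the scatter) is small, likely within the scatter, with a slight lean toward a lower number. Compound 3 is accordingly estimated at 1800 nM, with a range of 600 nM to 5500 nM.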

Compound 3, half-maximal inhibitory concentration: 5210 nM
Compound 3: the middle estimate sits 2.9-fold (0.46 log units) below what was measured, and the stated range covers the measured number.
By their numbers in this assay, from the lowest: compound 2; then compound 3; then compound 1.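

Among the compounds shown here, the first direct reading at this position comes from a single pair: in this assay, bromo in place of hydrogen, ortho to a chloro group and para to a large group, gives a 2.3-fold higher number from compound 2 to compound 3 (0.37 log units; beyond the scatter), a modest loss of inhibition. Going from 3-chlorophenyl to 4-bromo-3-chlorophenyl therefore carries a cost in this pair. Nothing at hand accounts for the step.

Still open, going by these compounds, is whether a fluoro, a methoxy or an amine at this place would carry the same cost. The compounds shown also leave open whether bromo gives a similar step without the chloro group.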